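This account rests on a few compounds, and the source may have more. Where it says the series, first, only, none or still open, it means among the compounds named here.

Measured compounds in a functional assay on LNCaP cells (Homo sapiens) for cytotoxicity, read by MTT assay, with a stated time of 48 h; on this read-out lower numbers stand for stronger inhibition and higher numbers for weaker inhibition:
compound 1 `Cn1cc(/C=C2/C(=O)Nc3ccccc32)c2cc(Nc3nccc(-c4ccccc4)n3)ccc21` – 13400 nM
compound 2 `Cn1cc(/C=C2/C(=O)Nc3ccccc32)c2cc(Nc3nccc(-c4ccc(Cl)cc4)n3)ccc21` – 6590 nM

On these two numbers compound 2 stands lowest; its nearest neighbour is compound 1, and the step of a 2.0-fold lower number from compound 1 to compound 2 (0.31 log units; beyond the scatter) separates them. Compound 3 `Cn1cc(/C=C2/C(=O)Nc3ccccc32)c2cc(Nc3nccc(-c4cccnc4)n3)ccc21` differs from compound 2 in one place: pyridin-3-yl in place of 4-chlorophenyl on an aromatic carbon. Going by the values given here, only one measured step bears on this change, namely a 2.0-fold lower number from compound 1 to compound 2 (0.31 log units; beyond the scatter), which shows that the chloro on the phenyl ring lowered the number modestly. Among the compounds with values here, compound 3 gives up that chloro, and no measured compound tells what the pyridin-3-yl ring does in its place. The expected outcome is therefore a modest rise in this assay, back toward the level of compound 1, with the ring nitrogen left as an open question. Compound 3 is expected to give 11000 nM in this assay, within 4500 nM to 27000 nM, meaning an estimated step of a 1.7-fold higher number from compound 2 to compound 3 (0.22 log units; within the scatter).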

Compound 3, half-maximal inhibitory concentration: 14200 nM
For compound 3 the middle estimate is 1.3-fold (0.11 log units) below the measured one; the range from low to high includes it.
By their numbers in this assay, from the lowest: compound 2; then compounds 1 and 3 (each within the scatter of the next).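

In this assay, replacing the 4-chlorophenyl with pyridin-3-yl gives up the gain seen with the chloro (a 2.2-fold higher number from compound 2 to compound 3 (0.33 log units; beyond the scatter)). Measured against the plain phenyl, the same ring with one carbon exchanged for nitrogen shows no change beyond the scatter (a 1.1-fold higher number from compound 1 to compound 3 (0.03 log units; within the scatter)), so at this position the pyridin-3-yl ring does not reproduce the effect of the 4-chlorophenyl group. No evidence is at hand that explains this result.

The compounds shown leave open whether the gain is specific to chloro or would also appear with fluoro, methoxy or a carboxylic acid on the phenyl ring. They also leave open whether pyridin-2-yl or pyridin-4-yl would match pyridin-3-yl, and whether a chloro on the pyridine ring would bring the number back down.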